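Swapping a dichlorophenyl for a methoxyphenyl group

The source may hold more compounds than are shown below. What is called first, only, known or untested is meant among the compounds shown, and "the series" means these compounds.

Compound 2 `Nc1nc(O)c2c(n1)n(C1OC(CO)[C@@H](O)[C@H]1O)c(=O)n2Cc1ccc(Cl)c(Cl)c1` and compound 1 `Nc1nc(O)c2c(n1)n(C1OC(CO)[C@@H](O)[C@H]1O)c(=O)n2C/C=C/c1ccccc1` share one core and differ only in the group carried on a saturated chain carbon bound to an aromatic nitrogen. In a functional assay on the whole organism with Mus musculus as the target (a lower number here means a smaller maximal response, a higher number a larger maximal response), compound 1 gives 5%, and compound 2 gives 0%. Compound 2 thus holds the lower of the two numbers, but the step of a number 5 percentage points lower from compound 1 to compound 2 (within the scatter) lies within the scatter, so the two compounds cannot be told apart. Compound 3 `COc1ccc(Cn2c(=O)n(C3OC(CO)[C@@H](O)[C@H]3O)c3nc(N)nc(O)c32)cc1` takes the next step: 4-methoxyphenyl in place of 3,4-dichlorophenyl on a saturated chain carbon bound to an aromatic nitrogen. Among the compounds with values here, the only measured step that bears on this place, a number 5 percentage points lower from compound 1 to compound 2 (within the scatter), shows that exchanging the whole group at this position left the maximal response essentially unchanged. With no step beyond the scatter to build on, the estimated change is a number 3 percentage points higher from compound 2 to compound 3 (within the scatter), nothing beyond the scatter. Compound 3 is therefore expected to give about 3%, most likely between 0% and 15%.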

Compound 3, largest response reached (reported as maximal response), in percent of the reference or control that the assay uses: 14%
Beside the measured number, compound 3's estimate is 11 percentage points below it; low and high end bracket the measured number.
By their numbers in this assay, from the lowest: compounds 2, 1 and 3 (each within the scatter of the next, the first and the last beyond it).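

In this assay, within the data shown here, the exchange gives a number 14 percentage points higher from compound 2 to compound 3 (beyond the scatter) and is the first step at this position to clear the scatter, so the group on the saturated chain carbon bound to an aromatic nitrogen can alter the maximal response, though only modestly. The comparison with 2-phenylethenyl gives a number 9 percentage points higher from compound 1 to compound 3 (within the scatter) and so does not separate that group from 4-methoxyphenyl. Nothing available explains why 4-methoxybenzyl and 3,4-dichlorobenzyl differ.

The compounds shown leave open whether the step comes from losing the two chlorines or from gaining the methoxy group, a question that an unsubstituted benzyl group could help to settle. They also leave open how a 4-hydroxybenzyl group or a longer chain ending in a phenyl ring would behave at this position.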